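This account rests on a few compounds, and the source may have more. Where it says the series, first, only, none or still open, it means among the compounds named here.

In a functional assay (aorta) with Oryctolagus cuniculus as the target (a higher number here means weaker binding, a lower number tighter binding), three compounds built on a shared core have been measured. Compound 1 `COc1cc(C(C)=O)ccc1OCCCN1CCC(C(c2ccc(Cl)cc2)c2ccc(Cl)cc2)CC1` gives 2.51 nM. Compound 2 `COc1cc(C(C)=O)ccc1OCCCCCN1CCC(C(c2ccc(F)cc2)c2ccc(F)cc2)CC1` gives 3.16 nM. Compound 3 `COC(=O)c1ccc(OCCCN2CCC(C(c3ccc(F)cc3)c3ccc(F)cc3)CC2)c(OC)c1` gives 1.26 nM, the lowest of the three numbers; its gap to compound 1 lies within the usual scatter of this assay, while its gap to compound 2 lies beyond it. Compound 4 `Fc1ccc(C(c2ccc(F)cc2)C2CCN(CCCOc3cccc4ccccc34)CC2)cc1` has not yet been measured in this assay. It differs from compound 3 in a single place: naphthalen-1-yl in place of 2-methoxy-4-(methoxycarbonyl)phenyl on an oxygen on a saturated carbon. Within the data shown here, each of the three measured compounds carries, on the oxygen of that chain, an aryl ring of the same general kind as the one that leaves here, so no measured pair shows how this assay responds to exchanging it for naphthalen-1-yl. Among the measured compounds shown here, with no measured step of this sort to lean on, the expectation for compound 4 is a modest weakening, a step of a 3.2-fold higher number from compound 3 to compound 4 (0.50 log units; beyond the scatter) that goes somewhat beyond the scatter without being large. Compound 4 is therefore estimated at 4 nM, with a range running from 1.3 nM to 13 nM.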

Compound 4, dissociation constant: 5.01 nM
For compound 4 the middle estimate is 1.3-fold (0.10 log units) below the measured one; low and high end bracket the measured number.
By their numbers in this assay, from the lowest: compounds 3, 1, 2 and 4 (each within the scatter of the next, the first and the last beyond it).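

In this assay, among these compounds, the exchange of 2-methoxy-4-(methoxycarbonyl)phenyl for naphthalen-1-yl on an oxygen on a saturated carbon gives a 4.0-fold higher number from compound 3 to compound 4 (0.60 log units; beyond the scatter) and so provides the first measured step at this position, one that is modest but lies beyond the scatter. The entering group has no hydrogen-bond acceptors where the leaving group has 3, and it brings two aromatic rings of carbon only in place of one, yet compound 4 still gives 5.01 nM in this assay, so this position accepts a complete exchange of its aryl group with only a modest loss. No measurement available here accounts for the size of this step.

Because the two groups differ in several features at once, the step cannot be assigned to any one of them, and a plain phenyl, a 2-methoxyphenyl, a carboxylic acid in place of the methoxycarbonyl or a naphthalen-2-yl would be needed to separate those features. As far as these compounds go, it also remains open whether the same exchange would give a step of similar size on a longer chain or with chlorine in place of fluorine on the two outer aromatic rings.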